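Notes on the step from carboxy to butylcarbonyl

The source may report more compounds than this note shows. Statements on the series, on what has been measured and on what is new or still open speak of the compounds shown alone.

Measured in an ADME assay on HEK-293T cells (Homo sapiens) for cytotoxicity, read by luminescence, with a stated time of 24 h; a higher number here means that more compound is tolerated, a lower number that less compound is tolerated:
compound 1 `COc1ccc(Cn2c(C(=O)N3CCCC3)cc3sccc32)cc1`: > 100000 nM
compound 2 `COc1ccc(Cn2c(C(=O)N3CCC(C(=O)O)CC3)cc3sccc32)cc1`: > 100000 nM

Both entries are limits of the assay, not numbers. Compound 2 stands at its limit of > 100000 nM. It shares that position with compound 1: the limit of > 100000 nM in this assay, at which 2 of the 2 values shown sit.

Compound 3 `CCCCC(=O)C1CCN(C(=O)c2cc3sccc3n2Cc2ccc(OC)cc2)CC1` differs from compound 2 in one place: butyl in place of hydroxy on a carbonyl carbon. In short, carboxy goes to butylcarbonyl.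

Going by the values given here, the one measured step, a step that the two limits leave unreadable from compound 1 to compound 2, has no readable size, so it offers no magnitude to carry over. It does show that compound 1, which lacks the carboxy group, and compound 2, which carries it, meet the same limit. No step beyond the scatter is therefore expected in this assay, and no direction is favoured. The expected step is a number no higher from compound 2 to compound 3 (the limit leaves the size open). The estimate for compound 3 is 100000 nM, with an expected range of 30000 nM to 200000 nM.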

Compound 3, half-maximal cytotoxic concentration: 38900 nM
The estimate for compound 3 lay 2.6-fold (0.41 log units) above the measured number; the range from low to high includes it.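

In this assay, butyl in place of hydroxy on a carbonyl carbon gives an at least 2.5-fold lower number from compound 2 to compound 3 (0.41 log units; beyond the scatter). Going by these compounds alone, this is the only readable step, and it shows that a change at this place, on a carbonyl carbon whose other neighbour is a saturated ring carbon, can move the number beyond the scatter and in the direction of less compound tolerated. Compound 3 is also the only compound shown that stands off the limit: the limit of > 100000 nM in this assay, at which 2 of the 3 values shown sit.

Going by these compounds, the full size of the step stays open, since compound 2 gives only a limit, and so does whether the butyl chain or the loss of hydroxy carries the step. A methyl ketone, a longer chain or an amine at the same place would help to separate these readings.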